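Adding a 4-methylpiperazinyl group to a weak cytotoxic lead

This account rests on a few compounds, and the source may have more. Where it says the series, first, only, none or still open, it means among the compounds named here.

Compound 1 `N=C(Nc1ccccc1)c1cc2c(-c3ccccc3)n[nH]c2c(NC2CCCCC2)n1` gives 1710 nM in a functional assay on MDA-MB-231 cells (Homo sapiens) for cytotoxicity, read by MTT assay, with a stated time of 72 h (a higher number here means a weaker inhibitor, a lower number a stronger inhibitor), while compound 2 `N=C(Nc1ccccc1)c1cc2c(-c3ccccc3)n[nH]c2cn1`, with hydrogen in place of cyclohexylamino on an aromatic carbon, gives 11000 nM, the highest of the two numbers; the step of a 6.4-fold higher number from compound 1 to compound 2 (0.81 log units; beyond the scatter) marks a modest loss. Compound 3 `CN1CCN(c2ccc(NC(=N)c3cc4c(-c5ccccc5)n[nH]c4cn3)cc2)CC1` differs from compound 2 by 4-methylpiperazin-1-yl in place of hydrogen on an aromatic carbon, placed para to a large group. For the measured compounds named here, no measured step touches this position, so the one known step is of little guide here. Compound 3 is therefore expected to lie close to compound 2, with a step of a 1.6-fold lower number from compound 2 to compound 3 (0.20 log units; within the scatter), estimated at 7000 nM within 2000 nM to 25000 nM.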

Compound 3, half-maximal inhibitory concentration: 15900 nM
For compound 3 the middle estimate is 2.3-fold (0.36 log units) below the measured one; low and high end bracket the measured number.
By their numbers in this assay, from the lowest: compound 1; then compounds 2 and 3 (each within the scatter of the next).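

In this assay, placing 4-methylpiperazin-1-yl on the aromatic carbon para to a large group gives a 1.4-fold higher number from compound 2 to compound 3 (0.16 log units; within the scatter) and so shows that this position accepts these 7 heavy atoms with no change that can be told from the scatter. No measurement at hand offers a reason for this result. From the compounds shown here alone, whether a carboxylic acid or a single chlorine atom at this position would read differently stays open. So does whether 4-methylpiperazin-1-yl would behave alike on compound 1, which carries cyclohexylamino.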